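Replacing the 2-aminoethyl chain of compound 3

The source may hold more compounds than are shown below. What is called first, only, known or untested is meant among the compounds shown, and "the series" means these compounds.

In a functional assay on Caco-2 cells (Homo sapiens), read by MTT assay, with a stated time of 48 h (on this read-out lower numbers stand for stronger inhibition and higher numbers for weaker inhibition), compound 1 (`CCn1c(C(=O)NCCN(C)C)ccc1C(CC)(CC)c1ccc(OCC(=O)C(C)(C)C)c(C)c1`) gives 1600 nM, compound 2 (`CCn1c(C(=O)NCCN)ccc1C(CC)(CC)c1ccc(OCC(=O)C(C)(C)C)c(C)c1`) gives 1900 nM and compound 3 (`CCn1c(C(=O)NCCN)ccc1C(CC)(CC)c1ccc(OCC(O)C(C)(C)C)c(C)c1`) gives 1000 nM. These three values all lie within the usual scatter of one another. Compound 4 (`CC[C@@H](C)[C@H](NC(=O)c1ccc(C(CC)(CC)c2ccc(OCC(O)C(C)(C)C)c(C)c2)n1CC)C(=O)O`) carries 1-carboxy-2-methylbutyl in place of 2-aminoethyl on an amide-type nitrogen. Among the compounds with values here, the only measured change on that chain, a 1.2-fold higher number from compound 1 to compound 2 (0.07 log units; within the scatter), altered just its amino end, while a 1.9-fold lower number from compound 2 to compound 3 (0.28 log units; within the scatter) concerned a different group. Both stayed within the scatter, and neither tests replacing the whole chain, so they offer only weak guidance. A moderate move towards weaker inhibition is expected, a 3.0-fold higher number from compound 3 to compound 4 (0.48 log units; beyond the scatter). Compound 4 is estimated at 3000 nM, with an expected range of 700 nM to 13000 nM.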

Compound 4, half-maximal inhibitory concentration: 3400 nM
Compound 4: the middle estimate sits 1.1-fold (0.05 log units) below what was measured; measured number inside the range.
By their numbers in this assay, from the lowest: compounds 3, 1, 2 and 4 (each within the scatter of the next, the first and the last beyond it).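

Within the data shown here, replacing the whole 2-aminoethyl chain on the amide-type nitrogen with 1-carboxy-2-methylbutyl gives a 3.4-fold higher number from compound 3 to compound 4 (0.53 log units; beyond the scatter), the first step here beyond the scatter. Altering only the amino end gave a 1.2-fold higher number from compound 1 to compound 2 (0.07 log units; within the scatter), so this position responds to a full chain replacement more clearly than to that smaller edit. No measured evidence explains the shift.

The change removes the amine and adds both a carboxylic acid and a branched chain, so these contributions remain unseparated. A methyl ester of that acid, or a plain 2-methylbutyl chain without the acid, would help to separate them.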